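Cyanomethyl in Place of Methyl and Dog Half-Life

This account rests on a few compounds, and the source may have more. Where it says the series, first, only, none or still open, it means among the compounds named here.

Compound 1, `COCC1(COC)Oc2ccc(C#N)cc2[C@@H](Nc2ccc(=O)n(C)n2)[C@@H]1O`: 0.0533 h
Compound 2, `CCn1nc(N[C@@H]2c3cc(C#N)ccc3OC(COC)(COC)[C@H]2O)ccc1=O`: 0.0867 h
Compound 3, `COCC1(COC)Oc2ccc(C#N)cc2[C@@H](Nc2ccc(=O)n(CC3CC3)n2)[C@@H]1O`: 0.175 h

In an ADME assay on the whole organism (blood) for pharmacokinetics, with Canis familiaris (Canis lupus familiaris) as the target (on this read-out higher numbers stand for a longer-lived compound and lower numbers for a shorter-lived compound), compound 1 stands lowest of the three measured compounds, with compound 2 nearest and compound 3 furthest. Compound 4, `COCC1(COC)Oc2ccc(C#N)cc2[C@@H](Nc2ccc(=O)n(CC#N)n2)[C@@H]1O`, differs from compound 1 by cyano in place of hydrogen on a saturated chain carbon bound to an aromatic nitrogen. Two measured steps alter the same place. One is a 1.6-fold higher number from compound 1 to compound 2 (0.21 log units; within the scatter). The other is a 3.3-fold higher number from compound 1 to compound 3 (0.52 log units; beyond the scatter). Only the cyclopropyl moved the number beyond the scatter, while methyl stayed within it. Cyano, like methyl, brings no ring, so only a small rise, if any, is expected here. Compound 4 is expected to give 0.07 h, within a range from 0.03 h to 0.16 h. The expected step is therefore a 1.3-fold higher number from compound 1 to compound 4 (0.12 log units; within the scatter), within the scatter.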

Compound 4, half-life: 0.0517 h
Compound 4: the middle estimate sits 1.4-fold (0.13 log units) above what was measured; measured number inside the range.
By their numbers in this assay, from the lowest: compounds 4, 1 and 2 (each within the scatter of the next); then compound 3.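

In this assay, putting cyano on this saturated chain carbon gives a 1.0-fold lower number from compound 1 to compound 4 (0.01 log units; within the scatter) and a 1.7-fold lower number from compound 2 to compound 4 (0.22 log units; within the scatter), so neither the cyanomethyl nor the ethyl group stands apart from the methyl group. Cyclopropyl does stand apart from cyano, with a 3.4-fold lower number from compound 3 to compound 4 (0.53 log units; beyond the scatter), which leaves it alone among the groups shown at this place. No measured evidence explains this difference. From the compounds shown here alone, whether another ring, such as cyclobutyl, would match cyclopropyl remains open. So does the effect of a longer chain or an amine here.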